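Imidazolylethyl chain at the limit of the series

The source may hold more compounds than are shown below. What is called first, only, known or untested is meant among the compounds shown, and "the series" means these compounds.

Values in a functional assay on KB cells (Homo sapiens) for antiproliferative activity, read by MTT assay, with a stated time of 48 h; a higher number here means a weaker inhibitor, a lower number a stronger inhibitor:
- compound 1 `Cn1cc(C2=C(c3nn(CCn4ccnc4)c4ncccc34)C(=O)N(c3ccccc3)C2=O)c2ccccc21`: > 100000 nM (a limit)
- compound 2 `Cn1cc(C2=C(c3nn(CCCn4cccc4)c4ncccc34)C(=O)NC2=O)c2ccccc21`: > 100000 nM (a limit)
- compound 3 `CN(C)CCCn1nc(C2=C(c3cn(C)c4ccccc34)C(=O)NC2=O)c2cccnc21`: > 100000 nM (a limit)

Compound 3 stands only at a limit, and no number is available for it. Within the data shown here, the same holds for the other two compounds, so the series so far comes down to the limit of > 100000 nM in this assay, at which 3 of the 3 values shown sit.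

Compound 4 `Cn1cc(C2=C(c3nn(CCn4ccnc4)c4ncccc34)C(=O)NC2=O)c2ccccc21` differs from compound 3 in one place: 1H-imidazol-1-yl in place of (dimethylamino)methyl on a saturated chain carbon, two bonds along the chain from an aromatic nitrogen. In words, this is 1H-imidazol-1-yl in place of (dimethylamino)methyl on a saturated chain carbon, two bonds along the chain from an aromatic nitrogen. Cut one bond further out, it reads 3-(dimethylamino)propyl to 2-(1H-imidazol-1-yl)ethyl.

Among the measured compounds shown here, the only measured step on this chain is a step that the two limits leave unreadable from compound 2 to compound 3, so no size can be carried over from it. Compound 1 already carries the 2-(1H-imidazol-1-yl)ethyl group, though its core is not that of compound 4. Compound 1 gives > 100000 nM, which is again a limit.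

No readable change is therefore expected in this assay, and a reported limit is the likeliest outcome. The expected change is an at least 1.1-fold lower number from compound 3 to compound 4 (0.04 log units; that floor lies within the scatter). The estimate for compound 4 is 90000 nM, with an expected range of 30000 nM to 100000 nM.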

Compound 4, half-maximal inhibitory concentration: > 100000 nM
Compound 4: a limit, no number (the forecaster's own chance of this, stated with the estimate: 80%); middle value at least 1.1-fold (0.04 log units) away from the limit.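

In this assay compound 4 gives > 100000 nM, a limit, so its steps from compound 1, compound 2 and compound 3 cannot be read. The series remains at a single value: the limit of > 100000 nM in this assay, at which 4 of the 4 values shown sit.

The compounds shown leave open what the side-chain change or the phenyl-to-hydrogen change does to the value in this assay.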